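A few compounds are considered here, and "the series" means these few. Any claim that something is new, unique, unknown or untested is made for them only; others in the source may bear on it.

Measured compounds:
Compound 1 `O=c1oc2ccc(Br)cc2c(=O)n1-c1ccc(F)cc1F` gives 16000 nM in an ADME assay on RAW264.7 cells (Mus musculus) for cytotoxicity, read by MTT assay, with a stated time of 24 h; a lower number here means that less compound is tolerated, a higher number that more compound is tolerated.
Compound 2 `O=c1oc2ccc(Br)cc2c(=O)n1-c1ccc(Br)cc1F` gives 7200 nM in this assay.
Compound 3 `O=c1oc2ccc(Br)cc2c(=O)n1-c1ccc(Cl)cc1F` gives 7500 nM in this assay.

Compound 1 stands highest of the three, so it is the best tolerated compound in the set; the nearest is compound 3, with a 2.1-fold lower number from compound 1 to compound 3 (0.33 log units; beyond the scatter), and the furthest is compound 2, with a 2.2-fold lower number from compound 1 to compound 2 (0.35 log units; beyond the scatter). Compound 4 `O=c1oc2ccc(Cl)cc2c(=O)n1-c1ccc(F)cc1F` has not yet been measured. It differs from compound 1 in one place: chloro in place of bromo on an aromatic carbon. The most relevant measured step is the same swap on the other aromatic ring, from compound 2 to compound 3, which gave a 1.0-fold higher number from compound 2 to compound 3 (0.02 log units; within the scatter). The two steps from compound 1, to compound 2 and to compound 3, each changed a different halogen and moved the number only modestly, and in the same direction for both halogens. On this basis the step from compound 1 to compound 4 is expected to stay within the scatter, no change at the digits printed from compound 1 to compound 4 (within the scatter). Compound 4 is therefore expected to give about 16000 nM in this assay, most likely between 8000 nM and 32000 nM.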

Compound 4, half-maximal cytotoxic concentration: 13400 nM
Compound 4: the middle estimate sits 1.2-fold (0.08 log units) above what was measured; the measured number falls inside the stated range.
By their numbers in this assay, from the lowest: compounds 2, 3, 4 and 1 (each within the scatter of the next, the first and the last beyond it).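

Exchanging bromo for chloro on the aromatic ring of the fused system makes no real difference in this assay, with a 1.2-fold lower number from compound 1 to compound 4 (0.08 log units; within the scatter). Until now, this exchange had been read only on the other aromatic ring, so the new result extends the finding to a second position: at both places, these two halogens give numbers that cannot be told apart. The two readings of the change also agree with each other: the same change on two cores in this assay, a 1.0-fold higher number (0.02 log units; within the scatter) from compound 2 to compound 3 and a 1.2-fold lower number (0.08 log units; within the scatter) from compound 1 to compound 4, 1.2-fold (0.09 log units) apart, within the scatter of two such steps.

Only bromo and chloro appear at this position, so these compounds cannot show whether the number would stay put with an amine, a carboxylic acid or a longer chain there. They also leave open how the compounds would behave in any cell type other than the one used in this assay.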